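Cell Growth Inhibition and a Longer Side Chain

The compounds below may be only part of what the source reports. "The series", "measured", "known", "first", "only" and "open" are said of these compounds alone.

Three compounds built on a shared core were tested in a functional assay on ACHN cells (Homo sapiens) for cytotoxicity; on this read-out lower numbers stand for stronger inhibition and higher numbers for weaker inhibition. Compound 1 `C=CC[n+]1cn(C)c2nc[nH]/c(=N\OC)c21` is the simplest of them. For compound 1 only a limit of the assay is reported, > 80000 nM. Compound 2 `Cn1c[n+](Cc2ccccc2)c2/c(=N/OC(C)(C)C)[nH]cnc21` is a related member of the group; for compound 2 in this assay no result was reported, "not determined" (no result reported). Compound 3 `CO/N=c1\[nH]cnc2c1[n+](C/C=C(\C)CCC=C(C)C)cn2C` carries the longest chain among the measured compounds. For compound 3 as well only a limit is reported, > 80000 nM. Compound 3 therefore stands where two of the three entries sit, at the edge of what the assay can report, which is summarised by the limit of > 80000 nM in this assay, at which 2 of the 3 values shown sit.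

Compound 4 `CO/N=c1\[nH]cnc2c1[n+](C/C=C(\C)CC/C=C(\C)CCC=C(C)C)cn2C` differs from compound 3 in one place: 3-methylbut-2-en-1-yl in place of hydrogen on a saturated chain carbon bound to a double-bonded chain carbon, so the chain grows by one such unit. Going by the values given here, no pair of measured compounds differs by a single change, and no measured step gives a scale for this one. Both measured entries sit at the limit; no trend can be extended from them. I expect compound 4 to remain weak, with the step of a number no higher from compound 3 to compound 4 (the limit leaves the size open) estimated as no change beyond the scatter. The expected value for compound 4 is 80000 nM, within a range from 20000 nM to 300000 nM.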

Compound 4, half-maximal inhibitory concentration: 40400 nM
For compound 4 the middle estimate is 2.0-fold (0.30 log units) above the measured one, within the range that was stated.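

In this assay, going by these compounds alone, compound 4 gives 40400 nM, the first true number in this group rather than a limit. Until this compound, the read-out gave only its edge: the limit of > 80000 nM in this assay, at which 2 of the 4 values shown sit. From the compounds shown here alone, putting 3-methylbut-2-en-1-yl in place of hydrogen on a saturated chain carbon bound to a double-bonded chain carbon gives an at least 1.9-fold lower number from compound 3 to compound 4 (0.29 log units; that floor lies within the scatter); this is only a floor, so extending the chain at this position may matter a great deal or hardly at all, and the true size of the step remains unknown.

The compounds shown leave open whether a still longer chain would move the number further, and whether the double bonds play any part, which a fully saturated chain of the same length could test. They also leave open whether chain length alone counts at this position, a question that an amine or a carboxylic acid at the far end of the chain could help to answer.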